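Naphthyloxyacetyl hydrazones: cytotoxicity on HEL cells

This account rests on a few compounds, and the source may have more. Where it says the series, first, only, none or still open, it means among the compounds named here.

Measured so far in an ADME assay on HEL cells (Homo sapiens) for cytotoxicity; a higher number here means that more compound is tolerated, a lower number that less compound is tolerated:
- compound 1 `O=C(COc1cccc2ccccc12)N/N=C/c1ccc(O)cc1`: 20 ug/mL
- compound 2 `O=C(COc1cccc2ccccc12)N/N=C/c1ccccc1Br`: value given as a limit, >= 20 ug/mL
- compound 3 `Cc1ccc(/C=N/NC(=O)COc2cccc3ccccc23)cc1`: 20 ug/mL

Compound 3 stands level with compound 1 in this assay; the step of no change at the digits printed from compound 1 to compound 3 (within the scatter) lies within the scatter. The value of compound 2 is a limit of this assay and not a number, as noted in the limit of >= 20 ug/mL in this assay, at which 1 of the 3 values shown sits. The step of a number no lower from compound 1 to compound 2 (the limit leaves the size open) is therefore of unreadable size, as is a number no higher from compound 2 to compound 3 (the limit leaves the size open).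

Compound 4 `O=C(COc1cccc2ccccc12)N/N=C/c1ccccc1Cl` is not yet measured. The change from compound 3 is 2-chlorophenyl in place of 4-methylphenyl on a carbon with a double bond to nitrogen. Within the data shown here, the steps that bear on it are those involving compound 2, where a 2-bromophenyl sits at the same place: a number no lower from compound 1 to compound 2 (the limit leaves the size open) and a number no higher from compound 2 to compound 3 (the limit leaves the size open), both bounded only on one side. Among the measured compounds shown here, no measured step shows a change beyond the scatter, so no step beyond the scatter is expected for compound 4 in this assay, with some chance that only a limit is reported again. The expected step is no change at the digits printed from compound 3 to compound 4 (within the scatter). Compound 4 is estimated at 20 ug/mL, with a range from 10 ug/mL to 40 ug/mL.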

Compound 4, minimum cytotoxic concentration: 100 ug/mL
The estimate for compound 4 lay 5.0-fold (0.70 log units) below the measured number; measured number outside the range, above it.
By their numbers in this assay, from the lowest: compounds 1 and 3 (each within the scatter of the next); then compound 4.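

In this assay, the group on the carbon with a double bond to nitrogen can move the number beyond the scatter: a 5.0-fold higher number from compound 3 to compound 4 (0.70 log units; beyond the scatter), and a 5.0-fold higher number from compound 1 to compound 4 (0.70 log units; beyond the scatter). Among these compounds, the earlier readable step, between the 4-hydroxyphenyl of compound 1 and the 4-methylphenyl of compound 3, showed no such change, so 2-chlorophenyl is the first group to stand apart from these two. Compound 2 gives >= 20 ug/mL, which is a limit of the assay, and its steps to the other compounds cannot be read, leaving 2-bromophenyl and 2-chlorophenyl without a readable comparison: the limit of >= 20 ug/mL in this assay, at which 1 of the 4 values shown sits.

From the compounds shown here alone, whether the higher number follows the chloro group or its place on the ring remains open; a methyl in place of the chloro of compound 4, or a chloro in place of the methyl of compound 3, would separate the two. Also open, going by these compounds, is how an amine or a carboxylic acid on this phenyl ring would read in this assay.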